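Adding a methyl group to compound 3

This account rests on a few compounds, and the source may have more. Where it says the series, first, only, none or still open, it means among the compounds named here.

Compound 1 `CCOC(=O)c1nn(-c2ccccc2)c(-c2ccc(C)cc2)c1CNC(C)(C)C`: 68100 nM; > 585000 nM (2 entries)
Compound 2 `CC(C)(C)NCc1c(C(=O)O)nn(-c2ccccc2)c1-c1ccc(F)cc1`: > 680000 nM, a limit
Compound 3 `CC(C)(C)NCc1c(C(=O)O)nn(-c2ccccc2)c1-c1ccccc1`: > 716000 nM, a limit

All three compounds were tested in a functional assay on HT-29 cells (Homo sapiens) for inhibition, read by sulforhodamine B assay, with a stated time of 48 h; on this read-out lower numbers stand for stronger inhibition of growth and higher numbers for weaker inhibition of growth. There compound 3 has no exact number, only the limit > 716000 nM.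

Compound 4 `Cc1ccc(-c2c(CNC(C)(C)C)c(C(=O)O)nn2-c2ccccc2)cc1` differs from compound 3 in one place: methyl in place of hydrogen on an aromatic carbon, which is methyl in place of hydrogen on an aromatic carbon.

The closest measured change is a step that the two limits leave unreadable from compound 2 to compound 3, also made on an aromatic carbon. Its size cannot be read, so it offers no size to carry over, and no shift beyond the usual scatter is expected in this assay.

The expected change is an at least 1.0-fold lower number from compound 3 to compound 4 (0.01 log units; that floor lies within the scatter). For compound 4 the estimated value is 690000 nM, within an expected range of 250000 nM to 800000 nM.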

Compound 4, concentration for 50% growth inhibition: > 688000 nM
Compound 4 was reported as a limit; the forecaster's own chance of this, stated with the estimate: 90%; the middle value lies beyond the limit too.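

Among the compounds shown here, compound 2, compound 3 and compound 4 each carry only a limit, and no step between them can be read. The compounds shown leave open whether fluoro, hydrogen or methyl at this place changes growth inhibition at all.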